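A few compounds are considered here, and "the series" means these few. Any claim that something is new, unique, unknown or untested is made for them only; others in the source may bear on it.

Measured so far:
- Compound 1 `O=C(Nc1cccc(C(F)(F)F)c1)N[C@H]1CC[C@H](O)CC1` gives > 20000 nM
- Compound 2 `O=C(Nc1cccc(C(F)(F)F)c1)N[C@H]1CC[C@@H](Oc2ccc(F)cc2)CC1` gives 2600 nM
- Compound 3 `O=C(Nc1cccc(C(F)(F)F)c1)N[C@H]1CCC[C@H](Oc2ccc(C(F)(F)F)cc2)C1` gives 3800 nM

In a functional assay on CRL2813 cells (Homo sapiens) for cytotoxicity, read by sulforhodamine B assay, with a stated time of 5 days (a higher number here means a weaker inhibitor, a lower number a stronger inhibitor), compound 1 has no numerical value, only the limit > 20000 nM. This places it at the limit of > 20000 nM in this assay, at which 1 of the 3 values shown sits.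

Compound 4 `O=C(Nc1cccc(C(F)(F)F)c1)N[C@H]1CC[C@H](Oc2ccccc2C(F)(F)F)CC1` differs from compound 1 by a single change, (2-(trifluoromethyl)phenyl in place of hydrogen on an oxygen on a saturated carbon), which puts 2-(trifluoromethyl)phenyl in place of hydrogen on an oxygen on a saturated carbon.

Going by the values given here, no step between measured compounds is available as a guide. The nearest evidence is that compound 2, at 2600 nM, and compound 3, at 3800 nM, also carry an aromatic ring on an oxygen and both return a number in this assay. On that basis compound 4 is expected to fall in the same region, towards a stronger inhibitor than the limit of the assay. The expected size of the step is an at least 6.2-fold lower number from compound 1 to compound 4 (0.79 log units; beyond the scatter), and it remains an estimate resting on a limit.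

For compound 4 the estimated value is 3200 nM, with an expected range from 1300 nM to 8000 nM.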

Compound 4, half-maximal inhibitory concentration: 1400 nM
Estimate against measurement, compound 4: 2.3-fold (0.36 log units) above; measured number inside the range.
By their numbers in this assay, from the lowest: compounds 4, 2 and 3 (each within the scatter of the next, the first and the last beyond it). At a limit, above all of these: compound 1.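

In this assay compound 1 gives > 20000 nM as a limit of the assay and not a number. Placing 2-(trifluoromethyl)phenyl in place of hydrogen on the oxygen gives an at least 14-fold lower number from compound 1 to compound 4 (1.15 log units; beyond the scatter) and this is the first step here that changes one place alone. It shows that this single change at the oxygen, with the rest of the structure kept, is enough to turn a compound with no numerical value into one with a number in this assay.

Going by these compounds, whether the step belongs to the aromatic ring or to its trifluoromethyl group stays open, as does what a plain phenyl, a methyl or a carboxylic acid on the same oxygen would give. On these data alone, the full size of the step also stays open, because compound 1 has no number: the limit of > 20000 nM in this assay, at which 1 of the 4 values shown sits.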